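Swapping the distal dichlorophenyl for a carboxyphenyl

A few compounds are considered here, and "the series" means these few. Any claim that something is new, unique, unknown or untested is made for them only; others in the source may bear on it.

Compound 1 `O=C(O)c1cc(-c2ccc(-c3ccc(Cl)cc3Cl)cc2)n(-c2ccc(Cl)cc2Cl)n1` gives 11900 nM in an assay on isolated protein for inhibition of methionine--tRNA ligase, cytoplasmic (Homo sapiens) (on this read-out lower numbers stand for stronger inhibition and higher numbers for weaker inhibition), the lowest number of the three measured. Compound 2 `CCn1nc(C(=O)O)cc1-c1ccc(-c2ccc(Cl)cc2Cl)cc1` gives 46400 nM and compound 3 `O=C(O)c1cc(-c2ccc(-c3ccc(Cl)cc3Cl)cc2)n(Cc2ccncc2)n1` gives 26200 nM; the steps of a 3.9-fold higher number from compound 1 to compound 2 (0.59 log units; beyond the scatter) and a 2.2-fold higher number from compound 1 to compound 3 (0.34 log units; beyond the scatter) both alter the group on the aromatic nitrogen, and a 1.8-fold lower number from compound 2 to compound 3 (0.25 log units; within the scatter) stays within the scatter. Compound 4 `O=C(O)c1cccc(-c2ccc(-c3cc(C(=O)O)nn3-c3ccc(Cl)cc3Cl)cc2)c1` instead changes the far end of the core: 3-carboxyphenyl in place of 2,4-dichlorophenyl on an aromatic carbon. Going by the values given here, no measured step touches that position, so the three steps offer no direct guide. Compound 4 is therefore expected to land near compound 1 with a step of a 1.3-fold higher number from compound 1 to compound 4 (0.10 log units; within the scatter), an estimate of 15000 nM with a range from 5000 nM to 50000 nM.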

Compound 4, half-maximal inhibitory concentration: 40900 nM
For compound 4 the middle estimate is 2.7-fold (0.44 log units) below the measured one, within the range that was stated.
By their numbers in this assay, from the lowest: compound 1; then compounds 3, 4 and 2 (each within the scatter of the next).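

In this assay, going by these compounds alone, 3-carboxyphenyl in place of 2,4-dichlorophenyl at the far end of the core gives a 3.4-fold higher number from compound 1 to compound 4 (0.54 log units; beyond the scatter), so this position, untouched by the earlier steps, does respond to a change of group, though only modestly. No measurement available here bears on the cause of this step. This single exchange removes both chlorine atoms and adds a carboxylic acid, and the compounds shown do not separate the two. An unsubstituted phenyl, or the methyl ester of the same acid, at this position would help to tell them apart.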